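The compounds below may be only part of what the source reports. "The series", "measured", "known", "first", "only" and "open" are said of these compounds alone.

Compound 1 `O=S(=O)(NCCNCc1ccc(-c2ccccc2)cc1)c1cc(C(F)(F)F)cc(C(F)(F)F)c1` gives 2800 nM in a functional assay on HPAC cells (Homo sapiens) for inhibition, read by MTT assay, with a stated time of 72 h; on this read-out higher numbers stand for weaker inhibition of growth and lower numbers for stronger inhibition of growth.
Compound 2 `O=S(=O)(NCCCNCc1ccc(Cl)c(Cl)c1)c1cc(C(F)(F)F)cc(C(F)(F)F)c1` gives 2500 nM in this assay.
Compound 3 `COc1ccc(CNCCCNS(=O)(=O)c2cc(C(F)(F)F)cc(C(F)(F)F)c2)cc1OC` gives 3500 nM in this assay.

All three compounds share the same core and differ only in the aryl group carried on the chain. Compound 2 has the smallest number of the three, but its gaps to compound 1 and to compound 3 both fall within the scatter of repeated measurements, so no order among them can be read from these numbers.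

Compound 4 `O=S(=O)(NCCCNCc1ccccc1)c1cc(C(F)(F)F)cc(C(F)(F)F)c1` has not yet been measured. It differs from compound 2 in one place: phenyl in place of 3,4-dichlorophenyl on a saturated chain carbon bound to an amine nitrogen. Going by the values given here, the only measured step that bears on this change is the one at the same place, where a different aryl group was exchanged: a 1.4-fold higher number from compound 2 to compound 3 (0.15 log units; within the scatter). That step stayed within the scatter, which suggests that this assay responds little to what is carried at this position among the groups seen so far.

On that basis the step from compound 2 to compound 4 is expected to be small, at most a modest rise in the number: a 1.4-fold higher number from compound 2 to compound 4 (0.15 log units; within the scatter). Compound 4 is therefore estimated to give 3500 nM in this assay, with a likely range from 1500 nM to 8000 nM.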

Compound 4, concentration for 50% growth inhibition: 3200 nM
Beside the measured number, compound 4's estimate is 1.1-fold (0.04 log units) above it, and the stated range covers the measured number.
By their numbers in this assay, from the lowest: compounds 2, 1, 4 and 3 (each within the scatter of the next).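

Taking both chlorines off the ring gives a 1.3-fold higher number from compound 2 to compound 4 (0.11 log units; within the scatter), and taking both methoxy groups off gives a 1.1-fold lower number from compound 3 to compound 4 (0.04 log units; within the scatter). Going by these compounds alone, the earlier compounds compared only two rings that each carried two substituents, so they could not show what a bare phenyl ring would do at this place, on a saturated chain carbon bound to an amine nitrogen. In this assay, compound 4 now shows that phenyl cannot be told apart from 3,4-dichlorophenyl or 3,4-dimethoxyphenyl here, so within these three compounds neither pair of substituents makes a readable difference.

Still open, on these data alone, is whether a group of another kind, such as an amine or a carboxylic acid on the ring, or a pyridine ring in place of the phenyl, would move the number beyond the scatter. Compound 1 differs from the others in both its chain and its aryl group, so the effect of chain length cannot be read from these compounds, and a longer chain is also untested in what is shown here.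

No supporting measurement is available to explain these results.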